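The compounds below may be only part of what the source reports. "The series", "measured", "known", "first", "only" and "open" are said of these compounds alone.

Measured so far:
compound 1 `OC[C@H](NC1CCN(CCCc2c[nH]c3ccc(-n4ccnc4)cc23)CC1)c1ccccc1`: 74%
compound 2 `COC[C@H](NC1CCN(CCCc2c[nH]c3ccc(-n4cnnc4)cc23)CC1)c1ccccc1`: 93%
compound 3 `C[C@@H](NC1CCN(CCCc2c[nH]c3ccc(-n4ccnc4)cc23)CC1)c1ccccc1`: 65%

In a functional assay on CHO cells for activation of 5-hydroxytryptamine receptor 1D (Homo sapiens), read by GTPgammaS binding (a lower number here means a smaller maximal response, a higher number a larger maximal response), compound 1 holds the second highest of these three numbers. The step of a number 9 percentage points lower from compound 1 to compound 3 (within the scatter) lies within the scatter, while compound 2 stands higher than compound 1 by more than the scatter. Compound 4 `OC[C@H](NC1CCN(CCCc2c[nH]c3ccc(-n4cncn4)cc23)CC1)c1ccccc1` is not yet measured. It differs from compound 1 in one place: 1H-1,2,4-triazol-1-yl in place of 1H-imidazol-1-yl on an aromatic carbon. Among the measured compounds shown here, no measured step changes this ring alone; the only single step, a number 9 percentage points lower from compound 1 to compound 3 (within the scatter), alters the amine substituent instead, and compound 2 carries both a different ring and a different amine substituent. With nothing bearing directly on the change, the expected step is a number 4 percentage points higher from compound 1 to compound 4 (within the scatter), none beyond the scatter. Compound 4 is therefore estimated at 78%, between 60% and 95%.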

Compound 4, largest response reached (reported as efficacy), in percent of the reference or control that the assay uses: 77%
Beside the measured number, compound 4's estimate is 1 percentage points above it, and the stated range covers the measured number.
By their numbers in this assay, from the lowest: compounds 3, 1 and 4 (each within the scatter of the next, the first and the last beyond it); then compound 2.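

In this assay, among the compounds shown here, this is the first reading of the ring change on its own: 1H-1,2,4-triazol-1-yl in place of 1H-imidazol-1-yl gives a number 3 percentage points higher from compound 1 to compound 4 (within the scatter) and so leaves the maximal response indistinguishable. At this aromatic carbon, then, the ring can carry one more ring nitrogen with no change that this assay can resolve. Nothing available explains this result.

Still open, going by these compounds, is how a tetrazole or a pyridine ring would behave on this carbon. It is also unknown whether the same swap would give a similar result with the 1-phenylethyl group of compound 3 on the amine nitrogen.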